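Methyl ester series: bromophenyl in place of dimethoxyphenyl

A few compounds are considered here, and "the series" means these few. Any claim that something is new, unique, unknown or untested is made for them only; others in the source may bear on it.

Working notes on the shared core. Among the measured compounds shown here, compound 2 `COC(=O)/C=C1/SC(N2N=C(c3cc4ccccc4o3)CC2c2ccc(OC)c(OC)c2)=NC1=O` is the only member with a numerical result: in a functional assay on A549 cells (Homo sapiens) for antiproliferative activity, read by MTT assay, with a stated time of 96 h (a lower number here means a stronger inhibitor, a higher number a weaker inhibitor), compound 2 gives 0.967 ug/mL. Compound 1 `CCOC(=O)/C=C1/SC(N2N=C(c3cc4ccccc4o3)CC2c2cccc(Br)c2)=NC1=O` gives only a limit of the assay in this assay, > 5 ug/mL. The limit is noted as the limit of > 5 ug/mL in this assay, at which 1 of the 2 values shown sits. For the measured compounds named here, no step between measured compounds is available, since the two differ in more than one place.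

Compound 3 `COC(=O)/C=C1/SC(N2N=C(c3cc4ccccc4o3)CC2c2cccc(Br)c2)=NC1=O` has not been measured. It differs from compound 2 in one place: 3-bromophenyl in place of 3,4-dimethoxyphenyl on a saturated ring carbon. Compound 1 carries the same 3-bromophenyl and sits at the limit, > 5 ug/mL. On that basis a step toward weaker inhibition is expected, with a fair chance that only a limit is reported. The expected step is a 4.1-fold higher number from compound 2 to compound 3 (0.62 log units; beyond the scatter). For compound 3 the estimate in this assay is 4 ug/mL, within 1.5 ug/mL to 10 ug/mL.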

Compound 3, half-maximal inhibitory concentration: 4.29 ug/mL
Compound 3: the middle estimate sits 1.1-fold (0.03 log units) below what was measured, and the stated range covers the measured number.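

In this assay, the group on the saturated ring carbon now has a direct comparison with the methyl ester held constant, and 3-bromophenyl gives a weaker inhibitor than 3,4-dimethoxyphenyl: a 4.4-fold higher number from compound 2 to compound 3 (0.65 log units; beyond the scatter). Between the ethyl and methyl esters, which share the 3-bromophenyl, the data give only a floor: an at least 1.1-fold lower number from compound 1 to compound 3 (0.06 log units; that floor lies within the scatter). The size of that ester step cannot be read, as the result for compound 1 is a limit of the assay and not a number: the limit of > 5 ug/mL in this assay, at which 1 of the 3 values shown sits.

Going by these compounds, whether the step from the dimethoxyphenyl follows the bromine or the absence of the two methoxy groups stays open, and an unsubstituted phenyl or a 3-chlorophenyl on the same ring carbon would help separate the two. Also open, on these data alone, is how a carboxylic acid or an amide in place of the ester would read out.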